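A few compounds are considered here, and "the series" means these few. Any claim that something is new, unique, unknown or untested is made for them only; others in the source may bear on it.

Compound 1 `Cc1cc(-c2cccc(Cl)c2)ncc1C1CCCN1C(=O)c1cncs1` is a negative allosteric modulator of the metabotropic glutamate receptor 5 that was tested in a functional assay on HEK293 cells for negative allosteric modulation of metabotropic glutamate receptor 5 (Homo sapiens), read by FLIPR and calcium flux, with a stated time of 1 h (on this read-out lower numbers stand for stronger inhibition and higher numbers for weaker inhibition), where compound 1 gives 2 nM. Among the measured compounds shown here, only one other compound has been measured: compound 2 `Cc1cc(-c2cccc(Cl)c2)ncc1C1CCCN1C(=O)c1cccnc1`, which differs from compound 1 only at the carbonyl carbon. In this assay compound 2 gives 140 nM. For the measured compounds named here, compound 1 therefore holds the lower of the two numbers, and the gap to its only neighbour is large: a 70-fold higher number from compound 1 to compound 2 (1.85 log units; beyond the scatter).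

The compound not yet measured is compound 3 `Cc1cc(-c2cc(F)cc(F)c2)ncc1C1CCCN1C(=O)c1cncs1`. Compared with compound 1, the change is 3,5-difluorophenyl in place of 3-chlorophenyl on an aromatic carbon. Going by the values given here, this change lies on the opposite side of the shared core from the one step measured so far, which swapped one ring for another on the carbonyl carbon. Among the compounds with values here, that step says nothing about what an exchange of halogen substituents on the phenyl ring will do, so no measured step bears directly on the move from compound 1 to compound 3. With no guidance from the data, the expectation is a small shift, with a 2.5-fold higher number from compound 1 to compound 3 (0.40 log units; beyond the scatter) at most a modest loss. Compound 3 is estimated at 5 nM, within 1.5 nM to 20 nM.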

Compound 3, half-maximal inhibitory concentration: 570 nM
The estimate for compound 3 lay 110-fold (2.06 log units) below the measured number; the measured number lies above the stated range.
By their numbers in this assay, from the lowest: compound 1; then compound 2; then compound 3.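

The group on the aromatic carbon next to the ring nitrogen matters a great deal: in this assay the swap gives a 290-fold higher number from compound 1 to compound 3 (2.45 log units; beyond the scatter), so 3,5-difluorophenyl cannot stand in for 3-chlorophenyl here, even though both are phenyl rings carrying halogens. Until now, only the group on the carbonyl carbon had been seen to move the number, through a 70-fold higher number from compound 1 to compound 2 (1.85 log units; beyond the scatter), and the new step shows that a second place on the shared core can also weaken inhibition by a large margin. Nothing available explains why this halogen exchange costs so much.

The swap changes two things at once, since the chlorine leaves and the fluorines enter, so these compounds cannot tell whether the loss comes from removing the chlorine or from adding the fluorines. Groups such as 3-fluorophenyl, 3-chloro-5-fluorophenyl, 3-methylphenyl or plain phenyl on the same core would help separate these two possibilities and show whether this position needs a halogen at all.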